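Homologation of the benzylamine on the piperidine of compound 1

This account rests on a few compounds, and the source may have more. Where it says the series, first, only, none or still open, it means among the compounds named here.

Measured compounds:
compound 1, `c1ccc(CNC2CCN(CCCc3c[nH]c4ccc(-n5cnnc5)cc34)CC2)cc1`: 7.6 nM
compound 2, `COC[C@H](NC1CCN(CCCc2c[nH]c3ccc(Cn4cncn4)cc23)CC1)c1ccc(F)cc1`: 8.9 nM
compound 3, `CC(=O)Nc1ccc([C@H](C)NCC2CCN(CCCc3c[nH]c4ccc(-n5cnnc5)cc34)CC2)cc1`: 3 nM

All three were run in an assay on CHO cells for agonist activity at 5-hydroxytryptamine receptor 1D (Homo sapiens), read by GTPgammaS binding; a higher number here means that more compound is needed for the effect, a lower number that less compound is needed. Within this set compound 1 holds the second highest number. Its nearest neighbour is compound 2, whose value lies within the usual scatter of compound 1, so no order between those two can be read. The furthest is compound 3, whose lower number lies beyond the scatter and marks it as the most potent of the three measured entries.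

The next entry is compound 4, `c1ccc(CNCC2CCN(CCCc3c[nH]c4ccc(-n5cnnc5)cc34)CC2)cc1`, which keeps the shared core of compound 1 and changes it in one place: (benzylamino)methyl in place of benzylamino on a saturated ring carbon

Within the data shown here, no measured pair in the set isolates this one-carbon extension, so its effect has to be estimated. Compound 3 carries a differently built amine on its saturated ring and still gives 3 nM, so a change of this kind need not cost potency. The step is expected to be small, a 1.3-fold lower number from compound 1 to compound 4 (0.10 log units; within the scatter), with no clear direction beyond the scatter. For compound 4 the estimate is 6 nM, with a plausible range from 2 nM to 18 nM.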

Compound 4, half-maximal effective concentration: 5.6 nM
Beside the measured number, compound 4's estimate is 1.1-fold (0.03 log units) above it, within the range that was stated.
By their numbers in this assay, from the lowest: compounds 3, 4, 1 and 2 (each within the scatter of the next, the first and the last beyond it).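

In this assay, among these compounds, (benzylamino)methyl in place of benzylamino on the saturated ring carbon gives a 1.4-fold lower number from compound 1 to compound 4 (0.13 log units; within the scatter), the first pair in the set to isolate this change, and the added carbon at this position produces no readable shift. Compound 4 also gives compound 3 a partner that differs in one place: benzyl in place of 1-(4-acetamidophenyl)ethyl on the amine nitrogen gives a 1.9-fold higher number from compound 3 to compound 4 (0.27 log units; within the scatter), so this substituent change has no readable effect on the number either. No other data bear on these two steps.

From the compounds shown here alone, whether a longer chain than (benzylamino)methyl on the saturated ring carbon, or an amide in place of the amine, stays in the same range in this assay remains open. The methyl branch and the acetamido group within 1-(4-acetamidophenyl)ethyl also cannot be told apart, since the compounds shown only exchange that group as a whole.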